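Ester series on the shared core: methyl to hydrogen

The source may report more compounds than this note shows. Statements on the series, on what has been measured and on what is new or still open speak of the compounds shown alone.

Compound 2 `CCOC(=O)c1sc(-c2ccc(C)cc2)nc1O` carries an ethyl ester on the shared core. In an assay on HEK293 cells for inhibition of transient receptor potential cation channel subfamily M member 8 (Homo sapiens), read by FLIPR, with stated times of 5 min and 3 min (a lower number here means a stronger inhibitor, a higher number a weaker inhibitor), compound 2 gives 160 nM, the lowest of the two numbers in hand. Compound 3 `CCON(C)C(=O)c1sc(-c2ccccc2O)nc1O`, the nearest neighbour, gives 1500 nM in this assay, a gap beyond the scatter. For compound 1 `O=C(c1sc(-c2cccc(F)c2)nc1O)N1CCCOC1` this assay returns > 100000 nM, which is a limit and not a number.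

Compound 4 `CCOC(=O)c1sc(-c2ccccc2)nc1O` differs from compound 2 by hydrogen in place of methyl on an aromatic carbon. Among the measured compounds shown here, no measured pair isolates this change, so the step is expected to be small, toward a weaker inhibitor if anything, and may fall within the scatter. For compound 4 the estimate in this assay is 320 nM, in the range 100 nM to 1000 nM, an expected step of a 2.0-fold higher number from compound 2 to compound 4 (0.30 log units; within the scatter).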

Compound 4, half-maximal inhibitory concentration: 32 nM
For compound 4 the middle estimate is 10-fold (1.00 log units) above the measured one; the whole stated range lies above it.
By their numbers in this assay, from the lowest: compound 4; then compound 2; then compound 3. At a limit, above all of these: compound 1.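

With the ethyl ester held fixed on the shared core, the methyl para to a large group is not needed for inhibition: in this assay, hydrogen in place of methyl on this aromatic carbon gives a 5.0-fold lower number from compound 2 to compound 4 (0.70 log units; beyond the scatter). The earlier compounds shown here held no pair isolating this position, and this single change now shows that removing the methyl gives the stronger inhibitor. No measurement in hand bears on the cause of this step.

On these data alone, whether a chlorine or an amine at this position would lower the number further remains open. So does whether the step carries over to a carboxylic acid in place of the ethyl ester.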